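A few compounds are considered here, and "the series" means these few. Any claim that something is new, unique, unknown or untested is made for them only; others in the source may bear on it.

Working notes on the series. Two compounds have been run in a functional assay on the whole organism with Rattus norvegicus as the target, read by paw edema, with a stated time of 3 h, at a dose of 100 mg/kg by the oral route; a higher number here means more inhibition at the dose given (going by the name of the read-out), a lower number less inhibition. Compound 1, `Cc1ccc(-c2nc3ccccc3[nH]2)nc1C`, gives 37% in this assay. Compound 2, `CCc1ccc(-c2nc3ccccc3n2C)nc1`, gives 5% in this assay. Compound 2 stands lowest of the two numbers; the nearest is compound 1, higher by a gap beyond the scatter. Among the compounds with values here, the two differ in more than one place, so no single step between them can be isolated.

Compound 3, `CCc1ccc(-c2nc3ccccc3n2-c2ccccc2)nc1`, has not yet been measured. It differs from compound 2 in one place: phenyl in place of methyl on an aromatic nitrogen. Within the data shown here, no measured pair shows this change, so nothing in the data sets its size or direction. The step of a number 7 percentage points higher from compound 2 to compound 3 (within the scatter) is expected to be small, within the scatter of this assay. For compound 3 the expected value in this assay is 12%, with a range from 0% to 35%.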

Compound 3, a percentage reported as inhibition, in the whole organism at one dose (the size of the read-out at that dose, not a potency): 12%
Beside the measured number, compound 3's estimate shows no gap at the digits printed; the range from low to high includes it.
By their numbers in this assay, from the lowest: compounds 2 and 3 (each within the scatter of the next); then compound 1.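

On the aromatic nitrogen of the five-membered aromatic ring, phenyl in place of methyl gives a number 7 percentage points higher from compound 2 to compound 3 (within the scatter) in this assay. Within the data shown here, this is the first change that can be read in one place, and it shows that this nitrogen can carry a six-membered aromatic ring of carbon only or a single methyl with numbers that stay within the scatter of each other. Nothing available on these compounds points to a cause for this step.

Still open, going by these compounds, is how a carboxylic acid, an amine or a longer chain on the same nitrogen would read in this assay. On these data alone, the part played by the hydrogen on that nitrogen in compound 1 also stays open, since compound 1 differs from compound 2 and compound 3 in more than one place.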